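Swapping Methoxy for Chloro on the Best-Tolerated Compound

The compounds below may be only part of what the source reports. "The series", "measured", "known", "first", "only" and "open" are said of these compounds alone.

All three measured compounds share one core and have been tested in an ADME assay on MT4 cells (Homo sapiens) for cytotoxicity, read by MTT assay, with a stated time of 4 days; a higher number here means that more compound is tolerated, a lower number that less compound is tolerated. Compound 1 `N#Cc1ccc(Nc2nc(Oc3c(Br)cc(Br)cc3Br)c3ccccc3n2)cc1` gives 58000 nM. Among the measured compounds shown here, compound 3 `N#Cc1ccc(Nc2nc(Oc3ccccc3Cl)c3ccccc3n2)cc1` gives 38000 nM; the single change between them, a 1.5-fold lower number from compound 1 to compound 3 (0.18 log units; within the scatter), is within the scatter, so the two cannot be told apart. Compound 2 `COc1cc(C#N)cc(OC)c1Oc1nc(Nc2ccc(C#N)cc2)nc2ccccc12` gives 194000 nM, the highest of the three numbers, beyond the scatter from both compound 1 and compound 3, so compound 2 is the best tolerated here.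

Compound 4 `COc1cc(C#N)cc(Cl)c1Oc1nc(Nc2ccc(C#N)cc2)nc2ccccc12` is not yet measured. Against compound 2 it differs in one place: chloro in place of methoxy on an aromatic carbon. For the measured compounds named here, no measured step changes a methoxy into a chloro, so none bears directly on this change. Going by the values given here, the only step available, between compound 1 and compound 3, swaps one halogen-bearing ring for another on the same oxygen and stays within the scatter. With nothing pointing to a clear shift, the expected step of a 1.3-fold lower number from compound 2 to compound 4 (0.11 log units; within the scatter) is none beyond the scatter, perhaps leaning slightly toward the lower numbers of compound 1 and compound 3. The estimate for compound 4 is therefore 150000 nM, expected to fall between 60000 nM and 320000 nM.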

Compound 4, half-maximal cytotoxic concentration: 220000 nM
Beside the measured number, compound 4's estimate is 1.5-fold (0.17 log units) below it; measured number inside the range.
By their numbers in this assay, from the lowest: compounds 3 and 1 (each within the scatter of the next); then compounds 2 and 4 (each within the scatter of the next).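

Among the compounds shown here, this is the first direct reading of a methoxy-to-chloro swap: at this aromatic carbon, ortho to a large group and meta to a cyano group, the change gives a 1.1-fold higher number from compound 2 to compound 4 (0.05 log units; within the scatter) in this assay. The exchange removes 2 heavy atoms, one carbon and one oxygen, along with 1 hydrogen-bond acceptor, and puts a single chlorine in their place, yet compound 2 and compound 4 cannot be told apart in how well they are tolerated, so this one swap at this position leaves no readable mark on the result. No measurement shown here gives a reason for this outcome, so the lack of a readable change stays an observation and nothing more.

This is one step on one compound pair, so it does not show whether a methoxy-to-chloro swap would behave the same way elsewhere, including at the methoxy group that remains in compound 4. It also leaves open whether a quite different group at this position, such as an amine, a carboxylic acid or a longer alkoxy chain, would move the number beyond the scatter.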